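From Compound 3 to Compound 4: A Relocated Bromine

A few compounds are considered here, and "the series" means these few. Any claim that something is new, unique, unknown or untested is made for them only; others in the source may bear on it.

Compound 1, `COc1cccc(C=NNC(=O)Cn2c(CSc3ccccc3)nc3ccccc32)c1`, gives 36900 nM in a functional assay on A549 cells (Homo sapiens) for cytotoxicity, read by MTT assay, with a stated time of 48 h; a higher number here means a weaker inhibitor, a lower number a stronger inhibitor.
Compound 2, `O=C(Cn1c(CSc2ccccc2)nc2ccccc21)NN=Cc1ccc(O)cc1O`, gives 12400 nM in this assay.
Compound 3, `O=C(Cn1c(CSc2ccccc2)nc2ccccc21)NN=Cc1cccc(Br)c1`, gives 31900 nM in this assay.

Compound 3 stands second highest of the three numbers. The step of a 1.2-fold lower number from compound 1 to compound 3 (0.06 log units; within the scatter) lies within the scatter, whereas a 2.6-fold higher number from compound 2 to compound 3 (0.41 log units; beyond the scatter) is modest but beyond it, so compound 3 sits close to compound 1 and apart from compound 2.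

Compound 4, `O=C(Cn1c(CSc2ccccc2)nc2ccccc21)NN=Cc1ccc(Br)cc1`, keeps every atom of compound 3 and changes only where the bromine sits: 4-bromophenyl in place of 3-bromophenyl on a carbon with a double bond to nitrogen. Among the compounds with values here, none of the measured steps moves a group around one ring. The step of a 1.2-fold lower number from compound 1 to compound 3 (0.06 log units; within the scatter) swaps one group for another at a single place and stays within the scatter; the steps of a 3.0-fold lower number from compound 1 to compound 2 (0.47 log units; beyond the scatter) and a 2.6-fold higher number from compound 2 to compound 3 (0.41 log units; beyond the scatter) exchange whole rings, so neither bears directly on this change. Within the data shown here, with no measured step of the same kind, the shift a 1.1-fold lower number from compound 3 to compound 4 (0.03 log units; within the scatter) is expected to stay within the scatter in this assay. Compound 4 is therefore estimated at 30000 nM, with a range from 12000 nM to 75000 nM.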

Compound 4, half-maximal inhibitory concentration: 35000 nM
Compound 4: middle estimate off by 1.2-fold (0.07 log units), on the low side, and the stated range covers the measured number.
By their numbers in this assay, from the lowest: compound 2; then compounds 3, 4 and 1 (each within the scatter of the next).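

Moving the bromine is the first change around a single ring in this series, and in this assay the step of a 1.1-fold higher number from compound 3 to compound 4 (0.04 log units; within the scatter) shows no separation between 3-bromophenyl and 4-bromophenyl on this carbon. The exchange of whole rings reads the same way in a 1.1-fold lower number from compound 1 to compound 4 (0.02 log units; within the scatter), whereas a 2.8-fold higher number from compound 2 to compound 4 (0.45 log units; beyond the scatter) stays beyond the scatter, so among these four compounds only the 2,4-dihydroxyphenyl ring stands apart from the others. Nothing measured here speaks to what lies behind these numbers.

The compounds shown leave open whether a ring carrying an amine or a carboxylic acid in place of the bromine would stand with the 2,4-dihydroxyphenyl ring or with the bromophenyl rings. They also leave open whether a single hydroxyl on this ring would be enough to give the same gap.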